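The source may hold more compounds than are shown below. What is called first, only, known or untested is meant among the compounds shown, and "the series" means these compounds.

Values in a functional assay on MCF7 cells (Homo sapiens) for inhibition, read by MTT assay, with a stated time of 72 h; on this read-out higher numbers stand for weaker inhibition and lower numbers for stronger inhibition:
- Compound 1 `COc1cc(OC)c(OC)cc1/C=C/C(=O)c1cc(Cc2ccccc2)cc(Cc2ccccc2)c1`: 23300 nM
- Compound 2 `COc1cc(OC)c(OC)cc1/C=C/C(=O)c1ccc(O)cc1O`: 33800 nM
- Compound 3 `COc1cc(OC)c(OC)cc1/C=C/C(=O)c1cccc([N+](=O)[O-])c1`: > 150000 nM

The numbers for compound 1 and compound 2 lie within the usual scatter of repeated measurements, so these two cannot be told apart in this assay. Compound 3 gives > 150000 nM, which is a limit of the assay and not a number.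

The next compound to be tested is compound 4 `COc1cc(OC)c(OC)cc1/C=C/C(=O)c1ccc(O)cc1`, which differs from compound 2 in one place: hydrogen in place of hydroxy on an aromatic carbon. Hydrogen stands in place of hydroxy on an aromatic carbon, ortho to a large group and meta to a hydroxy group. The 2,4-dihydroxyphenyl group thus becomes 4-hydroxyphenyl.

Among the measured compounds shown here, no two measured compounds differ in only one place, so the size of this step has not been measured directly. Starting from compound 2 at 33800 nM, and with one hydroxy group still in place, the expected change in this assay is none beyond the scatter, with no firm direction. Compound 4 is expected at 30000 nM, with an estimated range of 12000 nM to 80000 nM. This expected value corresponds to an estimated step of a 1.1-fold lower number from compound 2 to compound 4 (0.05 log units; within the scatter).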

Compound 4, half-maximal inhibitory concentration: 182000 nM
For compound 4 the middle estimate is 6.1-fold (0.78 log units) below the measured one, outside the stated range (above it).
By their numbers in this assay, from the lowest: compounds 1 and 2 (each within the scatter of the next); then compound 4.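

Among the compounds shown here, the change from 2,4-dihydroxyphenyl to 4-hydroxyphenyl gives the first step at a single place: in this assay, the number moves by a 5.4-fold higher number from compound 2 to compound 4 (0.73 log units; beyond the scatter). Higher numbers mean weaker inhibition here, so this hydroxy group, ortho to a large group and meta to a hydroxy group, matters to the result, and the hydroxy group that stays in compound 4 does not keep the inhibition at the level of compound 2. Compound 3 has a limit and not a number, so it gives no way of placing compound 4 against it, and compound 4 itself reads high on the same scale: the limit of > 150000 nM in this assay, at which 1 of the 4 values shown sits.

From the compounds shown here alone, it remains open whether the hydroxy group itself is needed at this position, or whether an amine, a fluorine atom or a short chain such as ethyl on the same aromatic carbon would give a number closer to that of compound 2. Also open, going by these compounds, is the effect of replacing the remaining hydroxy group of compound 4 with hydrogen.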